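Methoxy in Place of Hydroxyamino: Compound 3 to Compound 4

The compounds below may be only part of what the source reports. "The series", "measured", "known", "first", "only" and "open" are said of these compounds alone.

Of the compounds shown here, three sharing one core have been tested in a functional assay on THP-1 cells (Homo sapiens) for antiproliferative activity, tested at 4 uM; a lower number here means a weaker effect, a higher number a stronger effect of the compound at the concentration tested. Compound 1 `CC(=O)Oc1ccc(CONC(=O)c2ccc(CS(=O)(=O)Nc3ccc4cc(C)c(=O)n(C)c4c3)cc2)cc1` gives 4%, compound 2 `Cc1cc2cc(NS(=O)(=O)c3cc(C(=O)NO)ccc3Cl)ccc2n(C)c1=O` gives 16%, and compound 3 `COc1ccc(C(=O)NO)cc1S(=O)(=O)Nc1ccc2c(c1)cc(C)c(=O)n2C` gives 0%. Within the data shown here, compound 3 stands at the bottom of these three numbers, though its gap to compound 1 is within the scatter, so the two cannot be told apart; only the step of a number 16 percentage points lower from compound 2 to compound 3 (beyond the scatter) lies beyond it. Compound 4 `COC(=O)c1ccc(OC)c(S(=O)(=O)Nc2ccc3c(c2)cc(C)c(=O)n3C)c1` differs from compound 3 in one place: methoxy in place of hydroxyamino on a carbonyl carbon. Among the measured compounds shown here, no measured step involves this change, so the only guide is that compound 3 and compound 1 both sit at the low end of this assay. The expected step is a number 2 percentage points higher from compound 3 to compound 4 (within the scatter), not beyond the scatter. Compound 4 is therefore estimated at 2%, from -8% to 12%.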

Compound 4, a percentage reported as inhibition, at one concentration (the size of the read-out at that concentration, not a potency): 40%
Estimate against measurement, compound 4: 38 percentage points below; measured number above the stated range.
By their numbers in this assay, from the lowest: compounds 3 and 1 (each within the scatter of the next); then compound 2; then compound 4.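

In this assay, methoxy in place of hydroxyamino on the carbonyl carbon gives a number 40 percentage points higher from compound 3 to compound 4 (beyond the scatter). This shows that the hydroxycarbamoyl group is not needed for a clear effect at this concentration, since methoxycarbonyl at the same place gives a much higher number. No available evidence explains this rise.

As far as these compounds go, it remains open whether a carboxylic acid, a plain amide or an ethoxycarbonyl group on this carbonyl carbon would give a similar number. From the compounds shown here alone, it is also open whether the same change would raise the number for compound 2, which carries chloro instead of methoxy.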